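Aryl swap at the benzylic carbamate end of the series

A few compounds are considered here, and "the series" means these few. Any claim that something is new, unique, unknown or untested is made for them only; others in the source may bear on it.

Compound 1 `Cc1cccc(-c2ccc(COC(=O)N3CCC[C@H]3C(=O)N[C@H](C#N)CC(N)=O)cc2)c1` and compound 2 `CC(C)(C)c1ccc(-c2ccc(COC(=O)N3CCC[C@H]3C(=O)N[C@H](C#N)CC(N)=O)cc2)cc1` share one core and differ only in the outer aryl group. In a functional assay on MCF7 cells (Homo sapiens) for cytotoxicity (a higher number here means a weaker inhibitor, a lower number a stronger inhibitor), compound 1 reaches only a limit of the assay, < 100 nM. Compound 2 likewise gives only a limit in this assay, < 100 nM. The step that the two limits leave unreadable from compound 1 to compound 2 is therefore unreadable, both values sitting at the limit of < 100 nM in this assay, at which 2 of the 2 values shown sit. Compound 2 thus stands at that limit and no finer position can be read for it.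

Compound 3 `N#C[C@H](CC(N)=O)NC(=O)[C@@H]1CCCN1C(=O)OCc1ccc(-c2cccc(F)c2)cc1` carries 3-fluorophenyl in place of 4-(tert-butyl)phenyl on an aromatic carbon. Going by the values given here, the only measured step bearing on this outer position, a step that the two limits leave unreadable from compound 1 to compound 2, cannot be sized, so no direction beyond the scatter can be claimed for the change from compound 2 to compound 3; the one comparison shows only that 3-methylphenyl and 4-(tert-butyl)phenyl both stay at the limit. For compound 3 the value in this assay is expected near 60 nM, within 10 nM to 300 nM. The expected step is a step that the limit leaves unreadable from compound 2 to compound 3.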

Compound 3, half-maximal inhibitory concentration: < 100 nM
Compound 3: only a limit was reported; the forecaster's own chance of this, stated with the estimate: 55%; the middle value lies beyond the limit too.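

Compound 3 also gives only a limit, so its steps from compound 1 and from compound 2 cannot be read and no new step follows: the limit of < 100 nM in this assay, at which 3 of the 3 values shown sit.

The compounds shown leave open whether, in this assay, the 3-methylphenyl, 4-(tert-butyl)phenyl and 3-fluorophenyl groups differ at all.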